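Halogen swap on a tricyclic core and cell toxicity

The compounds below may be only part of what the source reports. "The series", "measured", "known", "first", "only" and "open" are said of these compounds alone.

Compound 1 `O=C1C2C=C(I)C(CC2OCCCCCCO)[C@]12CO2`: > 50000 nM
Compound 2 `O=C1C2C=C(I)C(CC2c2ccccc2)[C@]12CO2`: > 50000 nM
Compound 3 `O=C1C2C=C(Br)C(CC2OCCCCCCO)[C@]12CO2`: > 50000 nM

In an ADME assay on Huh-7 cells (Homo sapiens) for cytotoxicity (on this read-out lower numbers stand for higher toxicity in this test and higher numbers for lower toxicity in this test), compound 1 reaches only the limit of > 50000 nM, so no number is known for it. Compound 3 likewise reaches only the limit of > 50000 nM. Compound 2 reaches only the limit of > 50000 nM. The change from compound 1 to compound 3 is bromo in place of iodo on a double-bonded ring carbon, and the step it made is a step that the two limits leave unreadable from compound 1 to compound 3. The difference between the cores of compound 1 and compound 2 is not broken down here. Compound 4 `O=C1C2C=C(Br)C(CC2c2ccccc2)[C@]12CO2` differs from compound 2 by the same change, (bromo in place of iodo on a double-bonded ring carbon). Since all three values sit at the limit of > 50000 nM in this assay, at which 3 of the 3 values shown sit, compound 4 is expected to stay there, an expected step that the limit leaves unreadable from compound 2 to compound 4. Compound 4 is estimated at 70000 nM, between 40000 nM and 200000 nM.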

Compound 4, half-maximal cytotoxic concentration: > 50000 nM
Compound 4 was reported as a limit (the forecaster's own chance of this, stated with the estimate: 85%); the middle value does not contradict the limit.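

Going by these compounds alone, compound 4 is reported only as a limit, > 50000 nM, and compound 2 is a limit too, so no step between them can be read. The compounds shown leave open whether bromo in place of iodo changes anything in this assay.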